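A few compounds are considered here, and "the series" means these few. Any claim that something is new, unique, unknown or untested is made for them only; others in the source may bear on it.

Measured compounds in a functional assay on M21 cells (Homo sapiens) for inhibition, read by sulforhodamine B assay, with a stated time of 48 h (a higher number here means a weaker inhibitor of growth, a lower number a stronger inhibitor of growth), so far
Compound 1 `c1cc(OC2CCCCCC2)ccc1NC1=NCCO1` gives 27100 nM
Compound 2 `O=C(CCl)NC(=O)Nc1ccc(OC2CCCCC2)cc1` gives 5000 nM

Of these two, compound 2 has the lower number (5000 nM) and so is the stronger inhibitor of growth. Compound 1 gives the higher number (27100 nM), and the gap between them lies beyond the usual scatter of repeated measurements.

The next compound, compound 3 `O=C(CCl)NC(=O)Nc1ccc(OC2CCCCCC2)cc1`, keeps everything in compound 2 except one group. It has cycloheptyl in place of cyclohexyl on an oxygen on an aromatic ring. Going by the values given here, no measured pair here shows what this swap does on its own. Compound 1 (27100 nM) also carries cycloheptyl, but it differs from compound 2 in the rest of its structure as well, so the pair cannot isolate the ring change. With so small a change, no shift beyond the scatter is expected in this assay, though a slightly lower number is possible. The estimate is a 1.3-fold lower number from compound 2 to compound 3 (0.10 log units; within the scatter) as the expected step. Compound 3 is expected to give 4000 nM (estimated range 1600 nM to 10000 nM).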

Compound 3, concentration for 50% growth inhibition: 5000 nM
The estimate for compound 3 lay 1.3-fold (0.10 log units) below the measured number; the measured number falls inside the stated range.
By their numbers in this assay, from the lowest: compounds 2 and 3 (each within the scatter of the next); then compound 1.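

In this assay, going by these compounds alone, the swap of cycloheptyl for cyclohexyl on an oxygen on an aromatic ring gives no change at the digits printed from compound 2 to compound 3 (within the scatter) and is the first direct reading of this change, showing that this position accepts the seven-membered ring in place of the six-membered one with no loss of growth inhibition. Compound 3 also links the two earlier compounds, which differed in two places: it shares cycloheptyl with compound 1, so the group on a nitrogen on an aromatic ring can now be read alone, and the open chain holding chlorine, in place of the five-membered non-aromatic ring with two hetero atoms, gives a 5.4-fold lower number from compound 1 to compound 3 (0.73 log units; beyond the scatter) in this assay. Nothing available explains either result.

The compounds shown leave open whether a cyclopentyl ring, a phenyl ring or a longer open chain on that oxygen would also leave the number unchanged. They also leave open which part of the chain on the nitrogen matters, such as whether a bromine or a plain hydrogen in place of the chlorine would keep the lower number.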